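Fluorinated phenyl variants in a guanidine series of histamine agonists

This account rests on a few compounds, and the source may have more. Where it says the series, first, only, none or still open, it means among the compounds named here.

Measured so far:
compound 1 `N/C(=N\CCC(c1ccc(O)cc1)c1ccccn1)NCCCc1c[nH]cn1` — 1
compound 2 `N=C(NCCCc1c[nH]cn1)NCCC(c1ccc(F)cc1)c1ccccn1` — 1

In a functional assay on cardiac atrium for agonist activity at histamine H2 receptor (Cavia porcellus) (a lower number here means a smaller maximal response, a higher number a larger maximal response), compound 1 gives 1. In this assay compound 2 gives 1; the two values stand level within the scatter. Compound 3 `N=C(NCCCc1c[nH]cn1)NCCC(c1cc(F)cc(F)c1)c1ccccn1` is not yet measured. It differs from compound 2 by 3,5-difluorophenyl in place of 4-fluorophenyl on a saturated chain carbon bound to an aromatic carbon and a saturated chain carbon. For the measured compounds named here, no step between measured compounds can guide this change; since compound 2 already reaches the reference response, the step a number 0.050 lower from compound 2 to compound 3 (within the scatter) is expected to be none beyond the scatter or at most a slight fall. Compound 3 is estimated at 0.95 in this assay, in the range 0.8 to 1.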

Compound 3, intrinsic activity: the largest response reached, as a fraction of the reference agonist's: 1
For compound 3 the middle estimate is 0.050 below the measured one; the measured number falls inside the stated range.
By their numbers in this assay, from the lowest: compounds 1, 2 and 3 (each within the scatter of the next).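

In this assay, 3,5-difluorophenyl in place of 4-fluorophenyl on the saturated chain carbon gives no change at the digits printed from compound 2 to compound 3 (within the scatter); the maximal response therefore holds with two fluorine atoms on this phenyl ring as well as with one. The step says nothing about potency, since the read-out reports only the largest response reached. Nothing available explains this tolerance. Still open, going by these compounds, is whether the response also holds with a trifluoromethyl, methoxy or amine group on this ring, or with a chlorine atom in place of fluorine.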